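The source may report more compounds than this note shows. Statements on the series, on what has been measured and on what is new or still open speak of the compounds shown alone.

Of the compounds shown here, three have so far been measured in a functional assay on MDA-MB-231 cells (Homo sapiens) for inhibition, read by MTT assay, with a stated time of 48 h; on this read-out higher numbers stand for weaker inhibition and lower numbers for stronger inhibition. Compound 1 `COc1cc(OC)c(-c2nc3cc(/C=C4\SC(=O)NC4=O)ccc3[nH]2)cc1OC` gives 24500 nM. Within the data shown here, compound 2 `COc1cc(OC)c(-c2nc3cc(/C=C4\SC(=O)N(CC(=O)N5CCOCC5)C4=O)ccc3[nH]2)cc1OC` gives 21300 nM; the single measured step, a 1.2-fold lower number from compound 1 to compound 2 (0.06 log units; within the scatter), concerns only the substituent on an amide-type nitrogen in a ring and leaves the aryl group untouched. Compound 3 `COc1cc(-c2nc3cc(/C=C4\SC(=O)N(CC(=O)N5CCCCC5)C4=O)ccc3[nH]2)cc(OC)c1OC` gives 34900 nM, the highest of the three numbers, but its gaps to compound 1 and to compound 2 both lie within the scatter, so the three compounds cannot be told apart on these data.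

Compound 4 `COc1cc(OC)c(-c2nc3cc(/C=C4\SC(=O)N(CC(=O)N5CCCCC5)C4=O)ccc3[nH]2)cc1OC` has not yet been measured. It differs from compound 3 in one place: 2,4,5-trimethoxyphenyl in place of 3,4,5-trimethoxyphenyl on an aromatic carbon. Among the measured compounds shown here, no measured step bears on this change directly. What the data do show is that compound 1 and compound 2, which both carry the 2,4,5-trimethoxyphenyl, sit within the scatter of compound 3, which carries the 3,4,5-trimethoxyphenyl. The step from compound 3 to compound 4 is therefore expected to be a 1.3-fold lower number from compound 3 to compound 4 (0.13 log units; within the scatter), nothing beyond the scatter. Compound 4 is expected to give 26000 nM in this assay, with a likely range from 12000 nM to 55000 nM.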

Compound 4, half-maximal inhibitory concentration: > 50000 nM
Compound 4 gave a limit, no number (the forecaster's own chance of this, stated with the estimate: 5%); middle value at least 1.9-fold (0.28 log units) away from the limit.
By their numbers in this assay, from the lowest: compounds 2, 1 and 3 (each within the scatter of the next). At a limit, above all of these: compound 4.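

In this assay compound 4 gives a limit and not a number: the limit of > 50000 nM in this assay, at which 1 of the 4 values shown sits. Swapping 3,4,5-trimethoxyphenyl for 2,4,5-trimethoxyphenyl on the aromatic carbon between two ring nitrogen atoms, with the same atoms joined differently, gives an at least 1.4-fold higher number from compound 3 to compound 4 (0.15 log units; that floor lies within the scatter), so this floor alone does not show that the change matters. Among these compounds, with the 2,4,5-trimethoxyphenyl kept, the group on the ring nitrogen does now show an effect: an at least 2.3-fold higher number from compound 2 to compound 4 (0.37 log units; beyond the scatter) is the only step here beyond the scatter, while an at least 2.0-fold higher number from compound 1 to compound 4 (0.30 log units; that floor lies within the scatter) stays at its edge.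

On these data alone, how far the true value of compound 4 lies past the limit remains open, and with it the real size of the aryl change. Also open, as far as these compounds go, is whether dimethylamino in place of piperidin-1-yl on the carbonyl carbon would behave like morpholin-4-yl or like piperidin-1-yl.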